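A Halogen Swap Before the Result Is Known

This account rests on a few compounds, and the source may have more. Where it says the series, first, only, none or still open, it means among the compounds named here.

Compound 1 `N=C(N)c1ccc(-c2ccc(-c3cncc4ccccc34)s2)s1`, measured in a functional assay on T47D cells (Homo sapiens) for inhibition, read by sulforhodamine B assay, with a stated time of 48 h (a lower number here means a stronger inhibitor of growth, a higher number a weaker inhibitor of growth), gives 1520 nM. Compound 2 `N=C(N)c1ccc(-c2ccc(-c3ccc(F)cc3)o2)o1` shares the amidine end, but in this assay compound 2 gives "not determined" (no result reported), so it stands nowhere on the scale yet. Compound 3 `N=C(N)c1ccc(-c2ccc(-c3ccc(Cl)cc3)o2)o1` differs from compound 2 only by chloro in place of fluoro on an aromatic carbon. Going by the values given here, with no measured pair showing what such a swap does here, no step size is predicted, and a change within the usual scatter is as plausible as a shift either way. Compound 3 is therefore expected to give about 1500 nM, within the range 300 nM to 8000 nM.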

Compound 3, concentration for 50% growth inhibition: 1710 nM
Beside the measured number, compound 3's estimate is 1.1-fold (0.06 log units) below it, within the range that was stated.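

No step can be read between compound 2 and compound 3: compound 2 carries no number in this assay. As far as these compounds go, what chloro in place of fluoro does to growth inhibition stays open, and no supporting data bear on it.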